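Methylsulfanyl for dimethylcarbamoyl on the benzylamide aryl ring

This account rests on a few compounds, and the source may have more. Where it says the series, first, only, none or still open, it means among the compounds named here.

Two members of the series have numbers in an assay on HeLa cells with Bile acid receptor (Homo sapiens) as the target, read by a luciferase reporter, with a stated time of 24 h (on this read-out lower numbers stand for an effect already at smaller amounts and higher numbers for an effect only at larger amounts of compound), so far. Compound 1 `CC(C)(C)c1ccc(C(=O)NCc2ccc(C(N)=O)cc2)cc1` carries a primary carboxamide and in this assay compound 1 gives 3800 nM. Compound 2 `CN(C)C(=O)c1ccc(CNC(=O)c2ccc(C(C)(C)C)cc2)cc1` differs only on the carbonyl carbon, and in this assay compound 2 gives 170 nM. Within the data shown here, the single measured step is a 22-fold lower number from compound 1 to compound 2 (1.35 log units; beyond the scatter). On the numbers shown, compound 2 stands lowest, with compound 1 as its only neighbour.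

Compound 3 `CSc1ccc(CNC(=O)c2ccc(C(C)(C)C)cc2)cc1` is the next entry. It differs from compound 2 by methylsulfanyl in place of dimethylcarbamoyl on an aromatic carbon. Among the measured compounds shown here, no measured step covers this change: the step from compound 1 to compound 2 only altered the substitution on the amide nitrogen while the carbonyl stayed in place, whereas here the whole dimethylcarbamoyl is exchanged for methylsulfanyl. That step showed the read-out to be sensitive to this part of the molecule, so a shift beyond the scatter is expected rather than none, and the direction is taken as upward, back toward the number of compound 1. The step expected in this assay is an 8.8-fold higher number from compound 2 to compound 3 (0.95 log units; beyond the scatter). Compound 3 is accordingly estimated at 1500 nM, within 300 nM to 8000 nM.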

Compound 3, half-maximal effective concentration: 100 nM
Compound 3: the middle estimate sits 15-fold (1.18 log units) above what was measured, outside the stated range (below it).
By their numbers in this assay, from the lowest: compounds 3 and 2 (each within the scatter of the next); then compound 1.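

In this assay the exchange on this aromatic carbon gives a 1.7-fold lower number from compound 2 to compound 3 (0.23 log units; within the scatter) and so leaves the two compounds within the scatter of each other, although dimethylcarbamoyl has 5 heavy atoms and methylsulfanyl has 2 heavy atoms. The carbonyl present in compound 1 and compound 2 is therefore not required for a number in this range, and the read-out at this position does not simply follow the number of heavy atoms; the primary carboxamide alone stands apart, with a 38-fold lower number from compound 1 to compound 3 (1.58 log units; beyond the scatter) in the same assay, a large step comparable to the one seen on going to the dimethylamide. Nothing shown explains why the primary carboxamide stands apart from the other two groups.

Still open, from the compounds shown here alone, is whether an amine, a carboxylic acid or a longer chain such as ethylsulfanyl on this aromatic carbon would stay level with compound 2 and compound 3 or move toward compound 1. Going by these compounds, the three compounds also share everything else, so the response to replacing the tert-butyl group or altering the central amide remains unknown, as does whether the pattern at this position would hold with such changes in place.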